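The source may hold more compounds than are shown below. What is called first, only, known or untested is meant among the compounds shown, and "the series" means these compounds.

Working notes on the series. Three compounds carry the shared core with a sulfonyl chain ending in a substituted amine nitrogen. Compound 1 `CC(C)(C)NC(=O)NCCS(=O)(=O)NC(=O)c1ccc(Nc2nc(NC3(c4ccc(Cl)cc4)CC3)nc(OCC(F)(F)F)n2)cc1` gives 93% in an ADME assay on microsomes from liver (Rattus norvegicus) for metabolic stability, with a stated time of 10 min; on this read-out higher numbers stand for a more stable compound and lower numbers for a less stable compound. Compound 2 `CC(C)C(=O)NCCS(=O)(=O)NC(=O)c1ccc(Nc2nc(NC3(c4ccc(Cl)cc4)CC3)nc(OCC(F)(F)F)n2)cc1` gives 84% in this assay, and compound 3 `O=C(NS(=O)(=O)CCNCc1ccccc1)c1ccc(Nc2nc(NC3(c4ccc(Cl)cc4)CC3)nc(OCC(F)(F)F)n2)cc1` gives 100%. Compound 3 holds the highest number of the three; its gap to compound 1 is within the scatter, whereas the step of a number 16 percentage points higher from compound 2 to compound 3 (beyond the scatter) is beyond it. The step of a number 7 percentage points higher from compound 1 to compound 3 (within the scatter) stays within the scatter.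

Compound 4 `COC(=O)NCCS(=O)(=O)NC(=O)c1ccc(Nc2nc(NC3(c4ccc(Cl)cc4)CC3)nc(OCC(F)(F)F)n2)cc1` is the next case. The change from compound 3 is methoxycarbonyl in place of benzyl on an amine nitrogen whose other neighbour is a saturated chain carbon. Among the compounds with values here, two measured steps bear on it, both running toward benzyl: from a carbamoyl group in compound 1 and from an isopropylcarbonyl group in compound 2, one within the scatter and one modest. Compound 4 reverses that direction with another carbonyl-bearing substituent, so a step downward from compound 3 of small to modest size is expected, with the two reference steps as its bounds. For compound 4 the estimate in this assay is 85%, spanning 72% to 97%, corresponding to the expected step of a number 15 percentage points lower from compound 3 to compound 4 (beyond the scatter).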

Compound 4, percent of the compound remaining: 100%
The estimate for compound 4 lay 15 percentage points below the measured number, and the stated range ends below it.
By their numbers in this assay, from the lowest: compounds 2, 1, 3 and 4 (each within the scatter of the next, the first and the last beyond it).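

In this assay the exchange of benzyl for methoxycarbonyl on this amine nitrogen gives no change at the digits printed from compound 3 to compound 4 (within the scatter) so the aromatic ring of benzyl is not needed here for a number level with compound 3. Within the data shown here, with the carbonyl kept, the group on it matters in one comparison, as methoxy in place of isopropyl gives a number 16 percentage points higher from compound 2 to compound 4 (beyond the scatter) and this is the only step to compound 4 that lies beyond the scatter. Methoxy in place of (tert-butyl)amino gives a number 7 percentage points higher from compound 1 to compound 4 (within the scatter) and compound 1 also has a number 9 percentage points lower from compound 1 to compound 2 (within the scatter) so compound 1 cannot be separated from either compound 2 or compound 4, and the dependence on the group on the carbonyl carbon rests on the single pair of compound 2 and compound 4.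

Still open, going by these compounds, is how this read-out responds when the 2-((methoxycarbonyl)amino)ethyl chain gives way to a free primary amine, a carboxylic acid or a longer chain carrying the same methoxycarbonyl group. No measurement shown here gives a reason for these numbers.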